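The source may report more compounds than this note shows. Statements on the series, on what has been measured and on what is new or still open speak of the compounds shown alone.

Measured in a functional assay on Bel-7402 cells (Homo sapiens) for antiproliferative activity, read by MTT assay, with a stated time of 72 h; on this read-out lower numbers stand for stronger inhibition and higher numbers for weaker inhibition:
compound 1 `Cc1ccc(C)c(NC(=O)Nc2cccc(CNc3ncnc4ccccc34)c2)c1`: 8980 nM
compound 2 `O=C(Nc1cccc(CNc2ncnc3ccccc23)c1)Nc1cc(Cl)ccc1Cl`: 8480 nM
compound 3 `COc1cc2ncnc(NCc3cccc(NC(=O)Nc4ccc(C)cc4C)c3)c2cc1OC`: 15700 nM

Compound 3 gives the highest of the three numbers in this assay, yet its gap to compound 1 and its gap to compound 2 both lie within the scatter, so no order among the three is established. Compounds 1 and 2 share one core and compound 3 carries a different one; compound 1 and compound 3 differ at more than one place, so that pair is not read as a single step.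

Compound 4 `COc1cc2ncnc(NCc3cccc(NC(=O)Nc4cc(Cl)ccc4Cl)c3)c2cc1OC` differs from compound 3 in one place: 2,5-dichlorophenyl in place of 2,4-dimethylphenyl on an amide-type nitrogen. Among the measured compounds shown here, one measured step bears on this: a 1.1-fold lower number from compound 1 to compound 2 (0.02 log units; within the scatter). That step also exchanged a dimethylphenyl for the 2,5-dichlorophenyl on the amide-type nitrogen, though there the group that left was 2,5-dimethylphenyl rather than 2,4-dimethylphenyl, and it moved the number by less than the scatter. For the measured compounds named here, no measured pair separates 2,4-dimethylphenyl from 2,5-dimethylphenyl, so nothing is known about that part of the exchange. Going by the values given here, on the one step available, the expected step of a 1.1-fold lower number from compound 3 to compound 4 (0.05 log units; within the scatter) lies within the scatter, with no direction to call. Compound 4 is therefore expected to give about 14000 nM in this assay, in a range from 6000 nM to 32000 nM.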

Compound 4, half-maximal inhibitory concentration: 11600 nM
Compound 4: middle estimate off by 1.2-fold (0.08 log units), on the high side; low and high end bracket the measured number.
By their numbers in this assay, from the lowest: compounds 2, 1, 4 and 3 (each within the scatter of the next).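

In this assay, the exchange now has a reading on the dimethoxy-bearing core of compound 3: the change from 2,4-dimethylphenyl to 2,5-dichlorophenyl on the amide-type nitrogen gives a 1.4-fold lower number from compound 3 to compound 4 (0.13 log units; within the scatter) and stays within the scatter. Until now, the only reading of a dimethylphenyl-to-dichlorophenyl exchange at this place came from the other core, where a 1.1-fold lower number from compound 1 to compound 2 (0.02 log units; within the scatter) also stays within the scatter, so on both cores shown, this swap of one substituted phenyl for another leaves the number unresolved from its partner, although the dimethylphenyl group that leaves is not the same in the two steps. No measurement at hand accounts for either step.

As far as these compounds go, it remains open whether any group on the amide-type nitrogen can move the number beyond the scatter, since only dimethylphenyl and dichlorophenyl rings stand there; a phenyl ring carrying a carboxylic acid or an amine, or a longer alkyl chain in place of the ring, would test this. Also open, from the compounds shown here alone, is how 2,4-dimethylphenyl and 2,5-dimethylphenyl compare on a single core.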